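Switching Thiophen-2-yl to Thiophen-3-yl on Two Cores

A few compounds are considered here, and "the series" means these few. Any claim that something is new, unique, unknown or untested is made for them only; others in the source may bear on it.

Of the compounds shown here, three have been measured in an assay on membranes from CHO cells for displacement of a labelled ligand from adenosine receptor A1 (Homo sapiens), read by scintillation counting, with a stated time of 60 min, tested at 1 uM; a higher number here means more inhibition at the concentration tested (going by the name of the read-out), a lower number less inhibition. Compound 1 `CC1=C(C(=O)OCc2ccccc2)C(c2cccs2)NC(=S)N1` gives 34%. Compound 2 `CC1=C(C(=O)OCc2ccccc2)C(c2ccsc2)NC(=S)N1` gives 3% in this assay. These two are built from the same atoms joined differently: thiophen-3-yl in place of thiophen-2-yl on a saturated ring carbon. That rearrangement produced a number 31 percentage points lower from compound 1 to compound 2 (beyond the scatter).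

Compound 3 `CCSC(=O)C1=C(C)NC(=O)NC1c1cccs1` rests on a different core; the difference between the two cores is not broken down here. In this assay compound 3 gives 6%, which lies within the scatter of compound 2 and well beneath compound 1.

Compound 4 `CCSC(=O)C1=C(C)NC(=O)NC1c1ccsc1` has not yet been measured. It relates to compound 3 as compound 2 relates to compound 1: thiophen-3-yl in place of thiophen-2-yl on a saturated ring carbon. The surroundings are not identical, though. In compound 1 the changed position sits next to the ring atom that bears a large group, while in compound 3 it sits next to the ring atom that bears a (ethylsulfanyl)carbonyl group (5 heavy atoms), so this is the same kind of change rather than the same change.

For the measured compounds named here, the first instance of this change cost a large step in this assay. Because compound 3 already gives only 6%, there is little room for a drop of that size, and the estimated step is a number 3 percentage points lower from compound 3 to compound 4 (within the scatter). Compound 4 is therefore expected to give about 3%, most likely between -6% and 12%.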

Compound 4, a percentage reported as inhibition, at one concentration (the size of the read-out at that concentration, not a potency): 11%
Compound 4: the middle estimate sits 8 percentage points below what was measured; the measured number falls inside the stated range.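

On the core of compound 3, thiophen-3-yl in place of thiophen-2-yl on a saturated ring carbon gives a number 5 percentage points higher from compound 3 to compound 4 (within the scatter) in this assay, so the two thiophene attachments cannot be told apart on this core. The large loss seen on the core of compound 1 therefore does not carry over to this second core, and the same swap reads differently on the two: the same change on two cores in this assay, a number 31 percentage points lower (beyond the scatter) from compound 1 to compound 2 and a number 5 percentage points higher (within the scatter) from compound 3 to compound 4, 36 percentage points apart, beyond the scatter of two such steps

This does not show which feature of the cores sets the two steps apart, as they differ in more than one place and the two pairs offer no way to separate those differences, nor does it predict how the swap would behave on a third core. All of these numbers are also readings at a single concentration, so they describe the size of the inhibition at that concentration and not a potency.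

The compounds shown leave open how other rings, such as furan-2-yl or pyridin-3-yl, would read on the same saturated ring carbon. They also leave open whether either thiophene attachment would behave differently with a carboxylic acid or a longer chain in place of the (ethylsulfanyl)carbonyl group.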